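Arylthiomethyl nucleosides: swapping the aryl substituent

The source may report more compounds than this note shows. Statements on the series, on what has been measured and on what is new or still open speak of the compounds shown alone.

Working notes on the series. Compound 1 `CCSc1ncnc2c1ncn2[C@@H]1O[C@H](CO)[C@@H](O)[C@H]1O` carries the shared core with an ethylsulfanyl group; in an assay on isolated protein for binding affinity to Equilibrative nucleoside transporter 1 (Homo sapiens) (a lower number here means a stronger inhibitor, a higher number a weaker inhibitor), compound 1 gives 57500 nM. Compound 2 `Cc1cccc(CSc2ncnc3c2ncn3[C@@H]2O[C@H](CO)[C@@H](O)[C@H]2O)c1` gives 12000 nM, and compound 3 `OC[C@H]1O[C@@H](n2cnc3c(CSc4ccccc4Br)ncnc32)[C@H](O)[C@@H]1O` gives 2400 nM. Compound 3 stands lowest of the three numbers; the nearest is compound 2, and the step of a 5.0-fold lower number from compound 2 to compound 3 (0.70 log units; beyond the scatter) lies beyond the scatter, as does the larger step of a 24-fold lower number from compound 1 to compound 3 (1.38 log units; beyond the scatter). The step of a 4.8-fold lower number from compound 1 to compound 2 (0.68 log units; beyond the scatter) is the smallest of the three.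

Compound 4 `O=[N+]([O-])c1cccc(SCc2ncnc3c2ncn3[C@@H]2O[C@H](CO)[C@@H](O)[C@H]2O)c1` is the next member. Relative to compound 3 the change is 3-nitrophenyl in place of 2-bromophenyl on a sulfur. Within the data shown here, no measured step alters the aryl group on the sulfur while keeping the ((aryl)sulfanyl)methyl arrangement; the steps that bear on this position only show that the ((2-bromophenyl)sulfanyl)methyl arrangement of compound 3 outperforms the ethylsulfanyl of compound 1 and the (3-methylbenzyl)sulfanyl of compound 2. With nothing tying the 3-nitrophenyl group to a known number, the expected step of a 1.5-fold higher number from compound 3 to compound 4 (0.16 log units; within the scatter) is taken as within the scatter, leaning slightly toward a higher number. Compound 4 is therefore estimated at 3500 nM, with a range from 1200 nM to 10000 nM.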

Compound 4, half-maximal inhibitory concentration: 4.79 nM
The estimate for compound 4 lay 730-fold (2.86 log units) above the measured number; measured number below the stated range.
By their numbers in this assay, from the lowest: compound 4; then compound 3; then compound 2; then compound 1.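

The aryl group on the sulfur turns out to be the most sensitive point seen so far in the series in this assay: with the ((aryl)sulfanyl)methyl arrangement held fixed, the swap gives a 500-fold lower number from compound 3 to compound 4 (2.70 log units; beyond the scatter), well beyond a 24-fold lower number from compound 1 to compound 3 (1.38 log units; beyond the scatter), the largest step among the first three compounds. The earlier steps shown here each replaced the whole arrangement on the aromatic carbon, whereas this one shows that exchanging 2-bromophenyl for 3-nitrophenyl on the sulfur, which replaces bromine with nitrogen and oxygen atoms and adds hydrogen-bond acceptors with no net charge on either group, is enough on its own to move the number by far more. No measurement on hand explains this step.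

This single pair changes both the substituent and its printed location on the aryl ring, so the step cannot be divided between the nitro group and where it sits. As far as these compounds go, how far the step carries over to other aryl groups, such as an aminophenyl, a cyanophenyl or an unsubstituted phenyl on the same sulfur, stays open.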